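Triazole-linked sulfonamides: a phenyl ring swap and expected potency

The source may report more compounds than this note shows. Statements on the series, on what has been measured and on what is new or still open speak of the compounds shown alone.

Measured compounds:
- compound 1, `O=c1[nH]cc(S(=O)(=O)Nc2ccc(-c3cn(-c4ccccc4)nn3)cc2)c(=O)[nH]1`: 7170 nM
- compound 2, `Cc1cccc(-n2cc(-c3ccc(NS(=O)(=O)c4c[nH]c(=O)[nH]c4=O)cc3)nn2)c1`: 6960 nM

Of the compounds shown here, two sharing the same core have been measured in a functional assay on A549 cells (Homo sapiens) for antiproliferative activity, read by MTT assay, with a stated time of 24 h; on this read-out lower numbers stand for stronger inhibition and higher numbers for weaker inhibition. Compound 1 gives 7170 nM, and compound 2 gives 6960 nM. Among the measured compounds shown here, the single measured step, a 1.0-fold lower number from compound 1 to compound 2 (0.01 log units; within the scatter), shows that placing a methyl group on the phenyl ring attached to the triazole nitrogen leaves the read-out unchanged within the scatter. Compound 2 therefore stands beside compound 1 with no separation that can be read as a difference.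

Compound 3, `O=c1[nH]cc(S(=O)(=O)Nc2ccc(-c3cn(-c4ccccc4F)nn3)cc2)c(=O)[nH]1`, has not yet been measured in this assay. It differs from compound 2 by 2-fluorophenyl in place of 3-methylphenyl on an aromatic nitrogen. For the measured compounds named here, the only step that bears on this position is the one from compound 1 to compound 2, which was flat, so nothing measured so far points toward a shift in either direction when the substituent on this ring is exchanged.

Compound 3 is accordingly expected to show a step of about a 1.0-fold higher number from compound 2 to compound 3 (0.00 log units; within the scatter), that is, none beyond the scatter. The estimate for compound 3 in this assay is 7000 nM, with a range from 3500 nM to 14000 nM.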

Compound 3, half-maximal inhibitory concentration: 5960 nM
Compound 3: the middle estimate sits 1.2-fold (0.07 log units) above what was measured; the range from low to high includes it.
By their numbers in this assay, from the lowest: compounds 3, 2 and 1 (each within the scatter of the next).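

Among the compounds shown here, the earlier step showed only that a methyl group on this ring left the read-out flat; the new compound extends this to a different substituent, a halogen, on the same ring attached to the aromatic nitrogen of the five-membered ring. In this assay, 2-fluorophenyl in place of 3-methylphenyl gives a 1.2-fold lower number from compound 2 to compound 3 (0.07 log units; within the scatter), and adding a fluoro group to the unsubstituted phenyl ring gives a 1.2-fold lower number from compound 1 to compound 3 (0.08 log units; within the scatter), so phenyl, 3-methylphenyl and 2-fluorophenyl cannot be told apart at this position, and neither change separates from the scatter. No measurement offered here explains why these exchanges leave the read-out flat.

All three compounds carry a six-membered aromatic ring of carbon only at this position, so the compounds shown leave open whether anything placed there can move the number beyond the scatter. A carboxylic acid or an amine on that ring, or a longer alkyl chain in place of the ring itself, might behave differently, and the flat steps among these three compounds say nothing about such groups or about changes elsewhere on the shared core.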